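This account rests on a few compounds, and the source may have more. Where it says the series, first, only, none or still open, it means among the compounds named here.

Measured so far:
- Compound 1, `Nc1nccc2cc(CNCCNc3ccccc3)ccc12`, gives 1480 nM in an assay on isolated protein for inhibition of Rho-associated protein kinase 1 (Homo sapiens), read by fluorescence polarization; on this read-out higher numbers stand for weaker inhibition and lower numbers for stronger inhibition
- Compound 2, `Nc1nccc2cc(CNCc3ccccc3)ccc12`, gives 6760 nM in this assay

Compound 2 stands highest of the two numbers; compound 1 gives the lower number, and that gap lies beyond the usual scatter. Compound 3, `Nc1nccc2cc(CNCc3cccc(Oc4ccccc4)c3)ccc12`, has not yet been measured. It differs from compound 2 by phenoxy in place of hydrogen on an aromatic carbon. Among the measured compounds shown here, no measured pair shows what this particular addition does in this assay, so any expectation rests only on the two values above. Compound 1 shows that a more extended molecule built on the shared core can go with a lower number than compound 2, and a phenoxy group extends compound 2 in a broadly comparable way, though nothing measured anchors this directly. A modest step toward a lower number is therefore expected, a 2.3-fold lower number from compound 2 to compound 3 (0.35 log units; beyond the scatter). Compound 3 is estimated at 3000 nM, within a range from 800 nM to 12000 nM.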

Compound 3, half-maximal inhibitory concentration: 575 nM
Estimate against measurement, compound 3: 5.2-fold (0.72 log units) above; measured number outside the range, below it.
By their numbers in this assay, from the lowest: compound 3; then compound 1; then compound 2.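

In this assay, the benzene ring of compound 2 proves to be a place where a change can strongly affect the read-out: phenoxy in place of hydrogen on an aromatic carbon, meta to a large group, gives a 12-fold lower number from compound 2 to compound 3 (1.07 log units; beyond the scatter). This is the first single-place change shown, and a lower number here stands for stronger inhibition, so this large added group goes with a clear gain rather than a loss. Nothing available explains why the number falls so far.

The compounds shown leave open whether the gain depends on the oxygen, on the second ring, or on this position on the ring. Compounds carrying a methoxy group here, a benzyl group here, or phenoxy elsewhere on the same ring could begin to separate these possibilities.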